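Changing the amine end of compound 1

The source may hold more compounds than are shown below. What is called first, only, known or untested is meant among the compounds shown, and "the series" means these compounds.

In a physicochemical assay for solubility, in phosphate buffer, measured as kinetic solubility, at pH 7.4 (on this read-out lower numbers stand for lower solubility and higher numbers for higher solubility), compound 1 `Cc1ccccc1-c1nc(CN2CCC(C(=O)NCCCN3[C@H](C)CCC[C@@H]3C)CC2)c(C)o1` gives > 69 ug/mL, which is a limit of the assay and not a number. Compound 4 `Cc1ccccc1-c1nc(CN2CCC(C(=O)NCCN3C[C@H](C)C[C@H](C)C3)CC2)c(C)o1` has not yet been measured. It differs from compound 1 as follows: 3,5-dimethylpiperidin-1-yl in place of (2,6-dimethylpiperidin-1-yl)methyl on a saturated chain carbon, two bonds along the chain from an amide-type nitrogen. Put simply, 3,5-dimethylpiperidin-1-yl stands in place of (2,6-dimethylpiperidin-1-yl)methyl on a saturated chain carbon, two bonds along the chain from an amide-type nitrogen.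

Within the data shown here, no measured pair makes this exact change. The nearest evidence comes from two compounds that already carry 3,5-dimethylpiperidin-1-yl. Compound 2 `Cc1oc(-c2c(F)cccc2F)nc1CN1CCC(C(=O)NCCCN2C[C@H](C)C[C@H](C)C2)CC1` gives > 72 ug/mL, again a limit. Compound 3 `Cc1oc(-c2c(Br)cccc2Br)nc1CN1CCC(C(=O)NCCCN2C[C@H](C)C[C@H](C)C2)CC1` gives 62.4 ug/mL, a true number. Among the measured compounds shown here, the only measured step, an at least 1.1-fold lower number from compound 2 to compound 3 (0.06 log units; that floor lies within the scatter), lies within the scatter and concerns a different place in the molecule. It therefore gives no ground for expecting a real shift in this assay. The expected step, a step that the limit leaves unreadable from compound 1 to compound 4, stays within the scatter. Compound 4 is estimated at 70 ug/mL, with an expected range from 45 ug/mL to 80 ug/mL.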

Compound 4, solubility: > 67 ug/mL
Compound 4 was reported as a limit (the forecaster's own chance of this, stated with the estimate: 60%); the middle value is on the limit's open side.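

In this assay, compound 1 and compound 4 are both reported only as limits, so the step between them cannot be read. The compounds shown leave open whether 3,5-dimethylpiperidin-1-yl in place of (2,6-dimethylpiperidin-1-yl)methyl changes this read-out at all, and by how much.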